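Methoxy patterns give way to a hydroxy group

A few compounds are considered here, and "the series" means these few. Any claim that something is new, unique, unknown or untested is made for them only; others in the source may bear on it.

compound 1 `COc1cccc(/C=C/C(=O)C(=Cc2cc(OC)c(OC)c(OC)c2)C(=O)/C=C/c2cccc(OC)c2OC)c1OC` gives 650 nM
compound 2 `COc1cccc(/C=C/C(=O)C(=Cc2ccc(OC)c(OC)c2OC)C(=O)/C=C/c2cccc(OC)c2OC)c1OC` gives 560 nM
compound 3 `COc1ccc(OC)c(/C=C/C(=O)C(=Cc2ccc(OC)c(OC)c2)C(=O)/C=C/c2cc(OC)ccc2OC)c1` gives 560 nM

In a functional assay on SW480 cells (Homo sapiens) for antiproliferative activity, read by sulforhodamine B assay, with a stated time of 48 h (on this read-out higher numbers stand for weaker inhibition and lower numbers for stronger inhibition), compound 3 stands at 560 nM and is level with compound 2 at 560 nM while compound 1 lies within the scatter of both. The next compound to be tested is compound 4 `COc1ccc(OC)c(/C=C/C(=O)C(=Cc2cc(OC)c(O)c(OC)c2)C(=O)/C=C/c2cc(OC)ccc2OC)c1` and the change from compound 3 is 4-hydroxy-3,5-dimethoxyphenyl in place of 3,4-dimethoxyphenyl on a double-bonded chain carbon bound to a double-bonded chain carbon which puts 4-hydroxy-3,5-dimethoxyphenyl in place of 3,4-dimethoxyphenyl on a double-bonded chain carbon bound to a double-bonded chain carbon.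

Going by the values given here, only one measured step touches this place. That step is a 1.2-fold lower number from compound 1 to compound 2 (0.06 log units; within the scatter) and it stays within the scatter. It exchanges one methoxy-bearing aryl group for another, so it is only an indirect guide. Among the compounds with values here, no measured compound carries a hydroxy group, and the data therefore cannot show what that group does in this assay here. As far as these compounds go, with so little to go on, no step beyond the scatter is expected, and the direction stays open. The expected step is a 1.1-fold lower number from compound 3 to compound 4 (0.05 log units; within the scatter) and it remains a cautious guess. For compound 4 the estimated value is 500 nM with an expected range from 220 nM to 1100 nM in this measurement.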

Compound 4, half-maximal inhibitory concentration: 500 nM
Compound 4: middle estimate and measured number agree at the digits printed, and the stated range covers the measured number.
By their numbers in this assay, from the lowest: compounds 4, 2, 3 and 1 (each within the scatter of the next).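

In this assay, replacing 3,4-dimethoxyphenyl with 4-hydroxy-3,5-dimethoxyphenyl on a double-bonded chain carbon bound to a double-bonded chain carbon gives a 1.1-fold lower number from compound 3 to compound 4 (0.05 log units; within the scatter). Going by these compounds alone, compound 1, compound 2 and compound 3 carry only methoxy groups on their aryl rings, so this step is the first direct reading of a hydroxy group at this place, and it shows that a group with a hydrogen-bond donor can stand here without taking the number beyond the scatter. No measurement is available that would explain this result or connect it to any property of the group.

The change adds a methoxy group as well as exchanging one for a hydroxy group, and no pair among the compounds shown separates these two parts, so the contribution of the hydroxy group alone remains unresolved. As far as these compounds go, it also remains open whether this place would accept an amine, a carboxylic acid or a longer chain such as an ethoxy group, and whether a hydroxy group would give a similar result on the two outer aryl rings.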